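Dimethylamino on the saturated ring of compound 1

The source may hold more compounds than are shown below. What is called first, only, known or untested is meant among the compounds shown, and "the series" means these compounds.

Measured in an ADME assay on microsomes from liver (Mus musculus, strain CD-1) for metabolic stability, read by LC-MS, using NADPH, tested at 1 uM; a lower number here means that the compound disappears faster, a higher number that the compound lasts longer
compound 1 `O=C(Nc1ccc(Cl)cc1)C1CCCN(C(=O)c2cccc(-c3ccco3)c2)C1` gives 0.0267 h
compound 2 `O=C(Nc1ccc(Cl)cc1)C1CCCN(C(=O)c2cccc(-c3cc[nH]n3)c2)C1` gives 0.0567 h
compound 3 `CC1(C(=O)Nc2ccc(Cl)cc2)CCCN(C(=O)c2cccc(-c3ccco3)c2)C1` gives 0.014 h

Compound 1 stands with one neighbour inside the scatter (a 1.9-fold lower number from compound 1 to compound 3 (0.28 log units; within the scatter)) and the other just beyond it (a 2.1-fold higher number from compound 1 to compound 2 (0.33 log units; beyond the scatter)). Compound 4 `CN(C)C1CC(C(=O)Nc2ccc(Cl)cc2)CN(C(=O)c2cccc(-c3ccco3)c2)C1` keeps the core of compound 1 and takes dimethylamino in place of hydrogen on a saturated ring carbon. The closest measured precedent is methyl in place of hydrogen on a saturated ring carbon (a 1.9-fold lower number from compound 1 to compound 3 (0.28 log units; within the scatter)), a step that stays within the scatter. The swap to 1H-pyrazol-3-yl (a 2.1-fold higher number from compound 1 to compound 2 (0.33 log units; beyond the scatter)) concerns the furan-2-yl group, which compound 4 retains, so it offers little guidance here. Among the compounds with values here, no measured compound carries dimethylamino, so the precedent is thin and either direction remains open. In this assay no step beyond the scatter is therefore expected, and the estimated step is small (a 1.1-fold higher number from compound 1 to compound 4 (0.05 log units; within the scatter)). For compound 4 the expected value is 0.03 h (estimated range 0.012 h to 0.08 h).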

Compound 4, half-life: 0.055 h
The estimate for compound 4 lay 1.8-fold (0.26 log units) below the measured number; the measured number falls inside the stated range.
By their numbers in this assay, from the lowest: compounds 3 and 1 (each within the scatter of the next); then compounds 4 and 2 (each within the scatter of the next).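

In this assay, dimethylamino on the saturated ring carbon two ring bonds from the ring nitrogen gives a 2.1-fold higher number from compound 1 to compound 4 (0.31 log units; beyond the scatter), so a change on the saturated ring now moves the number beyond the scatter, though only modestly. Within the data shown here, the one earlier change on a saturated ring carbon, methyl in place of hydrogen, gave a 1.9-fold lower number from compound 1 to compound 3 (0.28 log units; within the scatter) and stayed within the scatter, while the only earlier step beyond it, a 2.1-fold higher number from compound 1 to compound 2 (0.33 log units; beyond the scatter), came from the furan-2-yl group, which compound 4 retains. No measurement at hand explains the rise with dimethylamino, and the result therefore records the size and direction of the step without giving a cause.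

With a single substituent at this ring carbon, the compounds shown do not separate a contribution of the dimethylamino nitrogen from that of simply having a group at this place; a methyl, a hydroxyl, a primary amine or a carboxylic acid on the same carbon would bear on that. Also open, from the compounds shown here alone, is whether dimethylamino and 1H-pyrazol-3-yl, placed together on the core of compound 1, would add up in this assay.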